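A few compounds are considered here, and "the series" means these few. Any claim that something is new, unique, unknown or untested is made for them only; others in the source may bear on it.

Measured so far:
- compound 1 `O=C(/C=C/c1ccc(Cl)cc1)c1ccccc1`: 97.5%
- compound 2 `O=C(/C=C/c1ccccc1Cl)c1ccc(OCc2ccccc2)cc1`: 54.5%
- compound 3 `COc1cccc(/C=C/C(=O)c2ccc(OCc3ccccc3)cc2)c1`: 35.4%

In a functional assay on HCT-116 cells (Homo sapiens) for antiproliferative activity, read by sulforhodamine B assay, with a stated time of 3 days, tested at 25 uM (on this read-out higher numbers stand for a stronger effect at the one concentration tested and lower numbers for a weaker effect), compound 1 gives 97.5%, the highest of the three numbers shown; compound 2 sits lower with 54.5% and compound 3 lower still with 35.4%, both gaps beyond the scatter. For the measured compounds named here, the one step between measured compounds that differ in a single place, a number 19.1 percentage points lower from compound 2 to compound 3 (beyond the scatter), concerns an exchange of the whole aryl ring on the double-bonded chain carbon and was modest.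

Compound 4 `O=C(/C=C/c1ccc(F)cc1)c1ccccc1` differs from compound 1 in one place: fluoro in place of chloro on an aromatic carbon. Going by the values given here, no measured pair covers an exchange of one halogen for another on this ring, so the step from compound 2 to compound 3 bears on it only loosely, as a sign that changes on this ring move the read-out by a moderate amount. Compound 1 already stands close to the top of the scale, so little upward room remains. A small downward step is therefore expected for compound 4, estimated as a number 11.5 percentage points lower from compound 1 to compound 4 (beyond the scatter). A step within the scatter would also be consistent with what is known. The estimate for compound 4 is 86%, with a range from 62% to 99%.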

Compound 4, a percentage reported as inhibition, at one concentration (the size of the read-out at that concentration, not a potency): 86.8%
Compound 4: the middle estimate sits 0.8 percentage points below what was measured; measured number inside the range.
By their numbers in this assay, from the lowest: compound 3; then compound 2; then compound 4; then compound 1.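

The exchange of chloro for fluoro on an aromatic carbon para to a large group gives a number 10.7 percentage points lower from compound 1 to compound 4 (beyond the scatter) in this assay. This is the first step shown in which a halogen on this ring is replaced by another halogen, and it shows that the read-out responds to which halogen sits at this place, though only modestly. Compound 4 nevertheless stays high on the scale, so at the one concentration tested, fluoro keeps most of the effect seen with chloro, and nothing shown explains the difference between them.

As far as these compounds go, whether an amine, a trifluoromethyl group or a carboxylic acid at this place would keep the read-out as high remains open. Also open, from the compounds shown here alone, is whether the same halogen exchange would have a similar effect on a core carrying the benzyloxy group of compound 2.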